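The compounds below may be only part of what the source reports. "The series", "measured", "known", "first", "only" and "open" are said of these compounds alone.

In a functional assay on OVCAR-3 cells (Homo sapiens) for antiproliferative activity, read by spectrophotometry, with a stated time of 2 days (a higher number here means a weaker inhibitor of growth, a lower number a stronger inhibitor of growth), compound 1 `COc1cc(Nc2ncc(C(F)(F)F)c(N3Cc4cccc(N(C)S(C)(=O)=O)c4C3)n2)cc(OC)c1` gives 630 nM. Compound 2 `Cc1cc(Cl)ccc1Nc1ncc(C(F)(F)F)c(N2Cc3cccc(N(C)S(C)(=O)=O)c3C2)n1` gives only a limit, > 30000 nM. Compound 3 `Cc1ccc(Nc2ncc(C(F)(F)F)c(N3Cc4cccc(N(C)S(C)(=O)=O)c4C3)n2)c(C)c1` differs from it by methyl in place of chloro on an aromatic carbon, turning 4-chloro-2-methylphenyl into 2,4-dimethylphenyl. Among the compounds with values here, the one measured step, an at least 47-fold higher number from compound 1 to compound 2 (1.67 log units; beyond the scatter), was large, but it replaced 3,5-dimethoxyphenyl as a whole and does not test the chloro alone. Compound 3 still lacks that 3,5-dimethoxyphenyl group, so no recovery is expected in this assay. The expected change is a number no higher from compound 2 to compound 3 (the limit leaves the size open), none beyond the scatter. Compound 3 is estimated at about 30000 nM, within a range of 10000 nM to 60000 nM.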

Compound 3, concentration for 50% growth inhibition: > 30000 nM
Compound 3 was reported as a limit; the forecaster's own chance of this, stated with the estimate: 65%; the middle value lies on the limit itself.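

In this assay compound 3 gives > 30000 nM, which is a limit of the assay. The replacement of 3,5-dimethoxyphenyl by 2,4-dimethylphenyl gives an at least 47-fold higher number from compound 1 to compound 3 (1.67 log units; beyond the scatter), so the large loss also appears without any chloro on the ring. The effect of methyl in place of chloro cannot be read, because compound 2 and compound 3 sit at the same limit: the limit of > 30000 nM in this assay, at which 2 of the 3 values shown sit.

As far as these compounds go, whether a phenyl ring carrying an amine or a carboxylic acid would give a readable number in this assay stays open.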